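The source may hold more compounds than are shown below. What is called first, only, known or untested is meant among the compounds shown, and "the series" means these compounds.

Compound 1 `COc1ccc2c(N)c(C(=O)NCc3ccc(F)cc3F)c(=O)n(O)c2n1` and compound 2 `Nc1c(C(=O)NCc2ccc(F)cc2F)c(=O)n(O)c2ncc(CCCCCCOCc3ccccc3)cc12` share one core and differ only in the chain attached to it. In an ADME assay on HOS cells (Homo sapiens) for cytotoxicity, read by luminescence and ATP content, with a stated time of 48 h (on this read-out higher numbers stand for lower toxicity in this test and lower numbers for higher toxicity in this test), compound 1 gives 2200 nM, and compound 2 gives 14400 nM, the higher of the two numbers, separated from compound 1 by a gap beyond the usual scatter. Compound 3 `Nc1c(C(=O)NCc2ccc(F)cc2F)c(=O)n(O)c2ncc(CCCOCCO)cc12` has not yet been measured in this assay. It differs from compound 2 in a single place: 2-hydroxyethoxy in place of 3-(benzyloxy)propyl on a saturated chain carbon, three bonds along the chain from an aromatic carbon. Within the data shown here, no pair of measured compounds shows how a change of this kind acts in this assay, so the expectation rests on the two numbers alone. The value estimated for compound 3 in this assay is 8000 nM, with a range from 2500 nM to 25000 nM. This expected step, a 1.8-fold lower number from compound 2 to compound 3 (0.26 log units; within the scatter), runs downward and may well stay within the scatter.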

Compound 3, half-maximal cytotoxic concentration: > 250000 nM
Compound 3 ended at the assay's limit; the forecaster's own chance of this, stated with the estimate: 10%; middle value at least 31-fold (1.49 log units) away from the limit.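

In this assay, putting 2-hydroxyethoxy in place of 3-(benzyloxy)propyl on a saturated chain carbon, three bonds along the chain from an aromatic carbon, gives an at least 17-fold higher number from compound 2 to compound 3 (1.23 log units; beyond the scatter). This single pair shows that the read-out responds strongly to what the chain carries at this position, and that this change moves it toward lower toxicity in this test. Compound 3 stands at a limit of the assay and not at a number: the limit of > 250000 nM in this assay, at which 1 of the 3 values shown sits.

The change removes a group of 11 heavy atoms with one six-membered aromatic ring and brings in one of 4 heavy atoms with no ring and a hydroxyl, so the pair cannot say which of these differences carries the step. It also leaves open whether a longer chain ending in a hydroxyl, an amine or a carboxylic acid would read the same way.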